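Swapping the Aryl Group on Compound 2's Exocyclic Carbon

A few compounds are considered here, and "the series" means these few. Any claim that something is new, unique, unknown or untested is made for them only; others in the source may bear on it.

The series rests on a shared core carrying two aryl-bearing double-bonded chain carbons. Compound 1 `COc1ccccc1/C=c1\c(=O)[nH]/c(=C/c2cccc(Cl)c2Cl)c(=O)n1C` gives 200 nM in a functional assay on A549 cells (Homo sapiens) for cytotoxicity, read by CCK-8 assay, with a stated time of 72 h; a lower number here means a stronger inhibitor, a higher number a weaker inhibitor. Compound 2 `C=CCn1c(=O)/c(=C\c2cc(F)ccc2C)[nH]c(=O)/c1=C\c1ccccc1OC` gives 4900 nM, the second highest of the three numbers; its nearest neighbour is compound 3 `C=CCn1c(=O)/c(=C\c2ccccc2C(F)(F)F)[nH]c(=O)/c1=C\c1ccccc1OC`, which gives 7000 nM, and compound 1 is furthest from it, with a lower number beyond the scatter. Among the measured compounds shown here, the only measured step at the position in question, a 1.4-fold higher number from compound 2 to compound 3 (0.15 log units; within the scatter), lies within the scatter.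

Compound 4 `C=CCn1c(=O)/c(=C\c2cccc(Cl)c2Cl)[nH]c(=O)/c1=C\c1ccccc1OC` arises from compound 2 by the change (2,3-dichlorophenyl in place of 5-fluoro-2-methylphenyl on a double-bonded chain carbon bound to an aromatic carbon). For the measured compounds named here, the one measured step at this place, from compound 2 to compound 3, was within the scatter, which alone would suggest no step beyond it. Yet compound 4 differs only elsewhere in the shared core from the compound that carries the same 2,3-dichlorophenyl, and the number of compound 1, 200 nM, is far lower. Weighing both, compound 4 is expected to give roughly 1500 nM in this assay, within 300 nM to 6000 nM, an estimated step of a 3.3-fold lower number from compound 2 to compound 4 (0.51 log units; beyond the scatter).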

Compound 4, half-maximal inhibitory concentration: 2300 nM
Estimate against measurement, compound 4: 1.5-fold (0.19 log units) below, within the range that was stated.
By their numbers in this assay, from the lowest: compound 1; then compound 4; then compounds 2 and 3 (each within the scatter of the next).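

In this assay, among the compounds shown here, the aryl group on the double-bonded chain carbon proves able to move the number beyond the scatter: 2,3-dichlorophenyl gives a 2.1-fold lower number from compound 2 to compound 4 (0.33 log units; beyond the scatter) and also a 3.0-fold lower number from compound 3 to compound 4 (0.48 log units; beyond the scatter) in modest steps, whereas the one earlier step at this place stayed within the scatter. A larger step appears at the other place, where vinyl in place of hydrogen on a saturated chain carbon bound to an aromatic nitrogen gives a 12-fold higher number from compound 1 to compound 4 (1.06 log units; beyond the scatter) with 2,3-dichlorophenyl held constant. The 2,3-dichlorophenyl group thus does not by itself bring compound 4 to the number of compound 1 (200 nM).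

Still open, going by these compounds, is whether an amine or a carboxylic acid on this aryl group, or a longer chain in place of the vinyl, would shift the number further. The data shown offer no evidence on the reason for these steps.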